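Tert-butyl for ethyl on a dithiocarbonate-type sulfur, tested twice

A few compounds are considered here, and "the series" means these few. Any claim that something is new, unique, unknown or untested is made for them only; others in the source may bear on it.

Of the compounds shown here, three have been measured in a functional assay on HeLa cells (Homo sapiens) for antiproliferative activity, read by resazurin assay; a higher number here means a weaker inhibitor, a lower number a stronger inhibitor. Compound 1 `Cc1ccc(C(=O)CSC(=S)SC(C)(C)C)cc1` gives 31600 nM, compound 2 `CCSC(=S)SCC(=O)c1ccc(C)cc1` gives 3980 nM, and compound 3 `CCSC(=S)SCC(=O)c1ccc(Cl)c(Cl)c1` gives 7940 nM. Compounds 2 and 1 differ in one place, (tert-butyl in place of ethyl on a sulfur), and this change made a step of a 7.9-fold higher number from compound 2 to compound 1 (0.90 log units; beyond the scatter). Compound 3 shares the sulfur-rich chain of compound 2 but differs in the core; the difference between the two cores is not broken down here. Compound 4 `CC(C)(C)SC(=S)SCC(=O)c1ccc(Cl)c(Cl)c1` is not yet measured. It differs from compound 3 by tert-butyl in place of ethyl on a sulfur, the same change already seen between compounds 2 and 1, at the same place. Compound 4 is expected to show a 6.3-fold higher number from compound 3 to compound 4 (0.80 log units; beyond the scatter). This expectation rests on the earlier step of a 7.9-fold higher number from compound 2 to compound 1 (0.90 log units; beyond the scatter). Compound 4 is therefore estimated at 50000 nM, with a likely range from 15000 nM to 160000 nM.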

Compound 4, half-maximal inhibitory concentration: 10000 nM
Estimate against measurement, compound 4: 5.0-fold (0.70 log units) above; measured number below the stated range.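

In this assay, tert-butyl in place of ethyl on a sulfur gives a 1.3-fold higher number from compound 3 to compound 4 (0.10 log units; within the scatter), so the clear weakening seen on the core of compound 2 does not carry over to the core of compound 3. The two steps do not agree, and the effect of this change depends on the core that carries it: the same change on two cores in this assay, a 7.9-fold higher number (0.90 log units; beyond the scatter) from compound 2 to compound 1 and a 1.3-fold higher number (0.10 log units; within the scatter) from compound 3 to compound 4, 6.3-fold (0.80 log units) apart, beyond the scatter of two such steps. For the compounds shown here, with only two pairs, this shows that a step measured on one core cannot simply be transferred to the other, but it does not show which feature of the cores causes the gap or how a third core would behave.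

On these data alone, only ethyl and tert-butyl appear on this sulfur, so it remains open how a longer chain, such as n-hexyl, or a chain ending in an amine would behave on either core.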